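The compounds below may be only part of what the source reports. "The series", "measured", "known", "first", "only" and "open" are said of these compounds alone.

Working notes on a small set of 2-aminothiophene ketones, all run in an assay on CHO cells for displacement of a labelled ligand from adenosine receptor A1 (Homo sapiens), read by scintillation counting, tested at 10 uM; a higher number here means more inhibition at the concentration tested (going by the name of the read-out), a lower number less inhibition.

Compound 1 `Cc1csc(N)c1C(=O)c1ccc(Cl)cc1` gives 1% in this assay. Compound 2 `CC(C)(C)Cc1c(-c2cccc(F)c2F)sc(N)c1C(=O)c1ccc(Cl)cc1` gives 1%. Compound 3 `CC(C)(C)Cc1csc(N)c1C(=O)c1cccc(C(F)(F)F)c1` gives 1%. Compound 2 therefore stands level with compounds 1 and 3 at the digits recorded: against its nearest neighbour, compound 1, there is no change, and against compound 3 there is likewise no change, both within the usual scatter. Going by the values given here, nothing in these three numbers separates one compound from another, and no pair of measured compounds differs in a single place, so no measured step is available to lean on.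

Compound 4 `CC(C)(C)Cc1c(Br)sc(N)c1C(=O)c1ccc(Cl)cc1` is the next compound to be measured. Relative to compound 2 the change is bromo in place of 2,3-difluorophenyl on an aromatic carbon.

With all three measured compounds sitting at the same low reading, the expectation for compound 4 is that the change does not move the number beyond the scatter in either direction. Compound 4 is expected to give about 2% in this assay, within a range of -8% to 12%. The corresponding step expected is a number 1 percentage points higher from compound 2 to compound 4 (within the scatter), that is, none beyond the scatter.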

Compound 4, a percentage reported as inhibition, at one concentration (the size of the read-out at that concentration, not a potency): 1%
Beside the measured number, compound 4's estimate is 1 percentage points above it; the range from low to high includes it.
By their numbers in this assay, from the lowest: compounds 1, 2, 3 and 4 (each within the scatter of the next).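

This gives the series its first step that can be read in this assay: bromo in place of 2,3-difluorophenyl on an aromatic carbon, next to the ring sulfur and next to the ring atom that bears the neopentyl group, gives no change at the digits printed from compound 2 to compound 4 (within the scatter). Replacing a group of 8 heavy atoms carrying a six-membered aromatic ring with a single bromine atom therefore leaves the reading unmoved at this position, so neither of these two substituents stands apart from the other while the rest of compound 2 is kept. Nothing measured here offers an explanation for this flat result.

With both compounds reading so low, the step does not show whether this position can influence the reading at all, or whether any effect is hidden by the lack of signal across the shared core at the concentration tested. From the compounds shown here alone, whether a carboxylic acid or a morpholine on this aromatic carbon, or a longer chain in place of the neopentyl group, would raise the reading beyond the scatter remains open.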